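This account rests on a few compounds, and the source may have more. Where it says the series, first, only, none or still open, it means among the compounds named here.

Of the compounds shown here, two have been measured so far in a physicochemical assay for acid dissociation, and they stand apart. Compound 1 (`CCCCS(=O)(=O)c1ccc(O)c(C(=O)Nc2ccc(Br)cc2)c1`) carries a butyl chain and a 4-bromophenyl group and gives 5.2 on this scale. Compound 2 (`CCCCCCCCCCCCS(=O)(=O)c1ccc(O)c(C(=O)Nc2ccc(C(F)(F)F)cc2)c1`) carries a dodecyl chain and a 4-(trifluoromethyl)phenyl group and stands higher at 6.2 with a gap to compound 1 that lies beyond the scatter. These two differ in both places, so the measured numbers cannot show how much of the gap belongs to each.

Compound 3 (`CCCCCCCCCCCCS(=O)(=O)c1ccc(O)c(C(=O)Nc2ccc(Br)cc2)c1`) keeps the dodecyl chain of compound 2 and has bromo in place of trifluoromethyl on an aromatic carbon, para to a large group (bromo in place of trifluoromethyl on an aromatic carbon). For the measured compounds named here, no measured pair shows this change alone. Compound 3 shares its bromo with compound 1 and its chain with compound 2, but only one place separates it from compound 2, which at 6.2 serves as the closer guide. No step beyond the scatter is expected, and the estimated size is a number 0.10 log units higher from compound 2 to compound 3 (within the scatter) on this reading. The estimated value for compound 3 is 6.3 with an expected range from 5.7 to 6.7 for now.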

Compound 3, acid dissociation constant: 5.2
For compound 3 the middle estimate is 1.10 log units above the measured one; measured number below the stated range.
By their numbers in this assay, from the lowest: compounds 1 and 3 (each within the scatter of the next); then compound 2.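

In this assay, bromo in place of trifluoromethyl on an aromatic carbon, para to a large group, gives a number 1.00 log units lower from compound 2 to compound 3 (beyond the scatter) with the dodecyl chain held fixed, so this position on the ring can move the reading by itself. Octyl in place of hydrogen on a saturated chain carbon, four bonds along the chain from a sulfonyl sulfur, turns the butyl chain into the dodecyl chain and gives no change at the digits printed from compound 1 to compound 3 (within the scatter) when bromo stays in place, so the gap between compound 1 and compound 2 can now be followed through compound 3, and it appears in the ring step and not in the chain step. Nothing available here says why the swap on the ring shifts the reading while the longer chain does not.

For the compounds shown here, the ring position is covered by only two groups, so a nitrile, a methoxy group or an amine there could fall anywhere relative to these readings. From the compounds shown here alone, the chain step is also known only with bromo on the ring, and whether a carboxylic acid at the end of the chain would leave the reading equally unmoved remains open.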